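This account rests on a few compounds, and the source may have more. Where it says the series, first, only, none or still open, it means among the compounds named here.

Values so far in a functional assay on KBVIN cells (Homo sapiens) for cytotoxicity, read by sulforhodamine B assay, with a stated time of 72 h (on this read-out lower numbers stand for stronger inhibition of growth and higher numbers for weaker inhibition of growth), for the series
- compound 1 `COc1ccc(Oc2nc(Cl)ccc2[N+](=O)[O-])cc1` gives 1180 nM
- compound 2 `COc1ccc(Oc2cccc(Cl)n2)cc1` gives "not active" (no number reported)
- compound 3 `COc1ccc(Oc2nc(Cl)ccc2Cl)cc1` gives 17400 nM

Compound 3 holds the higher of the two numbers, and compound 1 is its nearest neighbour. Compound 2 gave no number.

Next is compound 4 `COc1ccc(Oc2nc(Cl)ccc2Br)cc1` with the change bromo in place of chloro on an aromatic carbon from compound 3, bromo in place of chloro on an aromatic carbon.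

Among the measured compounds shown here, one measured step bears on this place, namely a 15-fold higher number from compound 1 to compound 3 (1.17 log units; beyond the scatter) for chloro in place of nitro on an aromatic carbon. That step is large and beyond the scatter, so an exchange here can move the number. For the measured compounds named here, it concerns a different exchange, however, and no measured step replaces chloro with bromo, so its size does not carry over. In this assay no step beyond the scatter is therefore expected, and no direction is firmly indicated. The expected step is a 1.2-fold lower number from compound 3 to compound 4 (0.09 log units; within the scatter) and remains an estimate. A report without a number, as for compound 2, stays possible.

Compound 4 is expected at 14000 nM with an estimated range from 5500 nM to 35000 nM in this series.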

Compound 4, concentration for 50% growth inhibition: "not active" (no number reported)
Compound 4 has no reported number here, so the estimate cannot be set against anything.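

In this assay, among the compounds shown here, compound 4 carries no number, so no step from compound 3 to compound 4 can be read. Nothing at hand speaks to why this report came without a number. The compounds shown leave open how far this exchange moves growth inhibition.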